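One Aryl Swap in a Brine Shrimp Toxicity Series

This account rests on a few compounds, and the source may have more. Where it says the series, first, only, none or still open, it means among the compounds named here.

Measured so far:
Compound 1 `Cc1ccc(S(=O)(=O)NC(=O)Nc2ccccc2C(=O)/C=C/c2ccccc2O)cc1` in an ADME assay on the whole organism for cytotoxicity, with Artemia salina as the target, with a stated time of 24 h (a lower number here means that less compound is needed, a higher number that more compound is needed for the effect), gives 32.3 ug/mL.
Compound 2 `COc1cc(/C=C/C(=O)c2ccccc2NC(=O)NS(=O)(=O)c2ccc(C)cc2)ccc1O` in this assay gives 17.8 ug/mL.

Of the two numbers in this assay, compound 2 has the lower one, but the step of a 1.8-fold lower number from compound 1 to compound 2 (0.26 log units; within the scatter) is within the scatter, so the two compounds cannot be told apart on these data. Compound 3 `Cc1ccc(S(=O)(=O)NC(=O)Nc2ccccc2C(=O)/C=C/c2ccccc2[N+](=O)[O-])cc1` carries the change (2-nitrophenyl in place of 4-hydroxy-3-methoxyphenyl on a double-bonded chain carbon bound to a double-bonded chain carbon). For the measured compounds named here, the only measured step, from compound 1 to compound 2, exchanged the aryl group at this same place and stayed within the scatter, which suggests that the aryl group at this position has little influence in this assay. The step of a 1.4-fold higher number from compound 2 to compound 3 (0.15 log units; within the scatter) is therefore expected to stay within the scatter as well. For compound 3 the estimate in this assay is 25 ug/mL, with a range from 10 ug/mL to 60 ug/mL.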

Compound 3, concentration for half-maximal effect: 40.1 ug/mL
Compound 3: middle estimate off by 1.6-fold (0.21 log units), on the low side; low and high end bracket the measured number.
By their numbers in this assay, from the lowest: compounds 2, 1 and 3 (each within the scatter of the next, the first and the last beyond it).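

In this assay, for the compounds shown here, the exchange of 4-hydroxy-3-methoxyphenyl for 2-nitrophenyl gives the first step at this position to pass the scatter, though only modestly, with a 2.3-fold higher number from compound 2 to compound 3 (0.35 log units; beyond the scatter) on record. Going by these compounds alone, the narrower change of nitro in place of hydroxy on an aromatic carbon, at a 1.2-fold higher number from compound 1 to compound 3 (0.09 log units; within the scatter), stays within the scatter, so the position responds to one aryl exchange but not to the other, and the earlier idea that any aryl exchange here stays within the scatter holds for only two of the three pairs. Nothing measured here accounts for either step.

Every aryl group shown carries only hydroxy, methoxy or nitro, so the effect of an amine or a carboxylic acid on that ring remains open. Also open, on these data alone, is whether a nitro group alone, without the loss of methoxy, would give a step beyond the scatter in any other setting.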